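1H-pyrrol-2-yl for 3-chlorophenyl: expectation for compound 4

This account rests on a few compounds, and the source may have more. Where it says the series, first, only, none or still open, it means among the compounds named here.

Measured in a functional assay on 786-0 cells (Homo sapiens) for inhibition, read by sulforhodamine B assay, with a stated time of 48 h; on this read-out higher numbers stand for weaker inhibition of growth and lower numbers for stronger inhibition of growth:
- compound 1 `CC1=CC[C@H](C(C)(C)NC(=S)N/N=C/c2ccccc2)CC1` gives 9900 nM
- compound 2 `CC1=CC[C@H](C(C)(C)NC(=S)N/N=C/c2ccc(F)cc2)CC1` gives only a limit of the assay, > 100000 nM
- compound 3 `CC1=CC[C@H](C(C)(C)NC(=S)N/N=C/c2cccc(Cl)c2)CC1` gives 9200 nM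

Compound 3 holds the lowest of the two numbers; compound 1 sits within the scatter of it, a 1.1-fold lower number from compound 1 to compound 3 (0.03 log units; within the scatter). Compound 4 `CC1=CC[C@H](C(C)(C)NC(=S)N/N=C/c2ccc[nH]2)CC1` differs by 1H-pyrrol-2-yl in place of 3-chlorophenyl on a carbon with a double bond to nitrogen. The measured steps touch only substituents on the six-membered ring: an at least 10-fold higher number from compound 1 to compound 2 (1.00 log units; beyond the scatter) and an at least 10-fold lower number from compound 2 to compound 3 (1.03 log units; beyond the scatter), both beyond the scatter, while a 1.1-fold lower number from compound 1 to compound 3 (0.03 log units; within the scatter) is not. Going by the values given here, no step exchanges the ring itself, so the swap to the five-membered ring is untested here. A moderate rise in the number is expected, a 1.6-fold higher number from compound 3 to compound 4 (0.21 log units; within the scatter), and compound 4 is estimated at 15000 nM, between 4000 nM and 60000 nM.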

Compound 4, concentration for 50% growth inhibition: 20800 nM
The estimate for compound 4 lay 1.4-fold (0.14 log units) below the measured number; the range from low to high includes it.
By their numbers in this assay, from the lowest: compounds 3 and 1 (each within the scatter of the next); then compound 4. At a limit, above all of these: compound 2.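

In this assay, exchanging the six-membered ring itself has a modest but real price: a 2.3-fold higher number from compound 3 to compound 4 (0.35 log units; beyond the scatter), and likewise a 2.1-fold higher number from compound 1 to compound 4 (0.32 log units; beyond the scatter), so 1H-pyrrol-2-yl is tolerated at this place without matching 3-chlorophenyl or phenyl. Compound 2 is held only by a limit of the assay: the limit of > 100000 nM in this assay, at which 1 of the 4 values shown sits. Against that limit, an at least 4.8-fold lower number from compound 2 to compound 4 (0.68 log units; beyond the scatter), so the five-membered ring retains measurable growth inhibition where 4-fluorophenyl gives only the limit.

On these data alone, whether the ring's hydrogen-bond donor matters stays open, as does how a 1-methylpyrrol-2-yl or thiophen-2-yl group would read at this place.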